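The source may hold more compounds than are shown below. What is called first, only, known or untested is meant among the compounds shown, and "the series" means these compounds.

The series shares one core, carried by compound 1 `COC(=O)CC1CCN(C[C@H]2CN(c3ccc(-n4cc(-c5ccccn5)cn4)c(F)c3)C(=O)O2)CC1`, compound 2 `O=CNC[C@H]1CN(c2ccc(-n3cc(-c4ccccn4)cn3)c(F)c2)C(=O)O1` and compound 3 `CN(C)S(=O)(=O)NC[C@H]1CN(c2ccc(-n3cc(-c4ccccn4)cn3)c(F)c2)C(=O)O1`. In an ADME assay on HEK293-A cells (Homo sapiens) for cytotoxicity, read by MTT assay, with a stated time of 48 h (a lower number here means a stronger inhibitor, a higher number a weaker inhibitor), compound 1 gives 224 ug/mL, and compound 3 gives 249 ug/mL. For compound 2 the assay reports only a limit, > 400 ug/mL. Of the two plain numbers, compound 3 stands highest, though the step of a 1.1-fold higher number from compound 1 to compound 3 (0.05 log units; within the scatter) shows how small that gap is. The remaining steps read an at least 1.7-fold higher number from compound 1 to compound 2 (0.25 log units; that floor lies within the scatter) and an at least 1.6-fold lower number from compound 2 to compound 3 (0.20 log units; that floor lies within the scatter); the one limit in the set is the limit of > 400 ug/mL in this assay, at which 1 of the 3 values shown sits. Compound 4 `O=C(NC[C@H]1CN(c2ccc(-n3cc(-c4ccccn4)cn3)c(F)c2)C(=O)O1)C(F)F` has not yet been measured; it differs from compound 3 by (difluoromethyl)carbonyl in place of dimethylsulfamoyl on an amine nitrogen. The step from compound 2 to compound 3 bears most directly on this change because an at least 1.6-fold lower number from compound 2 to compound 3 (0.20 log units; that floor lies within the scatter) also exchanged the group on the amine nitrogen, and it did not leave the scatter even at its floor. Compound 4 is therefore expected to show a step of about a 1.2-fold higher number from compound 3 to compound 4 (0.08 log units; within the scatter). The estimate for compound 4 is 300 ug/mL, expected to lie between 150 ug/mL and 500 ug/mL.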

Compound 4, half-maximal inhibitory concentration: 167 ug/mL
For compound 4 the middle estimate is 1.8-fold (0.25 log units) above the measured one, and the stated range covers the measured number.
By their numbers in this assay, from the lowest: compounds 4, 1 and 3 (each within the scatter of the next). At a limit, above all of these: compound 2.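

On the amine nitrogen, (difluoromethyl)carbonyl in place of dimethylsulfamoyl stays small in this assay, a 1.5-fold lower number from compound 3 to compound 4 (0.17 log units; within the scatter), and the comparison with the piperidine side chain of compound 1 is equally small, a 1.3-fold lower number from compound 1 to compound 4 (0.13 log units; within the scatter). Among the compounds shown here, the new finding lies on the carbonyl carbon, where difluoromethyl in place of hydrogen gives the first step to clear the scatter, an at least 2.3-fold lower number from compound 2 to compound 4 (0.37 log units; beyond the scatter). That step has only a floor, as the entry for compound 2 is a limit and not a number: the limit of > 400 ug/mL in this assay, at which 1 of the 4 values shown sits.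

The compounds shown leave open whether the fluorines or simply a carbon substituent on the carbonyl carries this step. An acetyl group or a methoxycarbonyl group on the same amine nitrogen would help to separate the two readings.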